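Aryl carbamate variation on the shared core: next step

The source may hold more compounds than are shown below. What is called first, only, known or untested is meant among the compounds shown, and "the series" means these compounds.

Measured so far in a functional assay on PANC-1 cells (Homo sapiens) for inhibition, read by MTT assay, with a stated time of 24 h, tested at 10 uM; a lower number here means less inhibition, a higher number more inhibition at the concentration tested (going by the name of the read-out):
- compound 1, `COc1ccc(NC(=O)Oc2cc(=O)n(CCCO)c3c2CC(CC=C(C)C)C(C)(C)C3)cc1`: 0%
- compound 2, `CC(C)=CCC1Cc2c(OC(=O)Nc3ccc(F)cc3)cc(=O)n(CCCO)c2CC1(C)C`: 0%
- compound 3, `CC(C)=CCC1Cc2c(OC(=O)Nc3ccccc3F)cc(=O)n(CCCO)c2CC1(C)C`: 0%

Compound 3 stands level with compound 1 and compound 2 at the digits reported; no member of the series has shown inhibition in this assay so far. The three steps among them all read flat: no change at the digits printed from compound 1 to compound 2 (within the scatter), no change at the digits printed from compound 1 to compound 3 (within the scatter) and no change at the digits printed from compound 2 to compound 3 (within the scatter). Exchanging the aryl group on the amide-type nitrogen, or its substituent, has therefore not moved the read-out anywhere in the measured set.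

Compound 4, `CC(C)=CCC1Cc2c(OC(=O)Nc3ccc(Cl)cc3)cc(=O)n(CCCO)c2CC1(C)C`, continues the same kind of exchange: 4-chlorophenyl in place of 2-fluorophenyl on an amide-type nitrogen. Within the data shown here, the steps that bear on it are no change at the digits printed from compound 2 to compound 3 (within the scatter), which swaps one fluorophenyl for another on the same nitrogen, and no change at the digits printed from compound 1 to compound 2 (within the scatter), which exchanges one substituent for another on the aromatic carbon; both were within the scatter. Nothing in the series suggests that a chlorine on the phenyl ring would behave differently from a fluorine or a methoxy there, so no step beyond the scatter is expected in this assay, in either direction.

Compound 4 is thus expected to give 0%, within 0% to 12%, which means an expected step of no change at the digits printed from compound 3 to compound 4 (within the scatter).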

Compound 4, a percentage reported as inhibition, at one concentration (the size of the read-out at that concentration, not a potency): 0%
Compound 4: the middle estimate sits on the measured number at the digits printed, within the range that was stated.
By their numbers in this assay, from the lowest: compounds 1, 2, 3 and 4 (each within the scatter of the next).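

With chlorine now on the aryl group, 4-chlorophenyl in place of 2-fluorophenyl on an amide-type nitrogen gives no change at the digits printed from compound 3 to compound 4 (within the scatter) in this assay. Chloro in place of fluoro on an aromatic carbon gives no change at the digits printed from compound 2 to compound 4 (within the scatter), and chloro in place of methoxy gives no change at the digits printed from compound 1 to compound 4 (within the scatter), so the fluoro, methoxy and chloro aryl carbamates show no order among them at this position. No supporting data are available to account for this flat reading.

As far as these compounds go, it remains open whether a group of another kind on the phenyl ring, such as an amine or a carboxylic acid, or a longer chain in place of the aryl group on the amide-type nitrogen, would move the read-out in this assay. Since none of compounds 1 to 4 shows any inhibition at the concentration tested, these compounds also cannot show whether changes elsewhere on the shared core, or a higher concentration, would give a read-out at which aryl groups could be told apart.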